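This account rests on a few compounds, and the source may have more. Where it says the series, first, only, none or still open, it means among the compounds named here.

Of the compounds shown here, three have been measured. Compound 1 `Cc1cccc(Nc2nccc(-c3ccncc3)n2)c1` gives 8800 nM in a functional assay for inhibition, with Homo sapiens as the target; on this read-out lower numbers stand for stronger inhibition and higher numbers for weaker inhibition; compound 2 `CCc1cccc(Nc2nccc(-c3ccco3)n2)c1` gives 9700 nM; compound 3 `CCc1cccc(Nc2nccc(-c3ccncc3)n2)c1` gives 10600 nM. The step of a 1.2-fold lower number from compound 3 to compound 1 (0.08 log units; within the scatter) corresponds to hydrogen in place of methyl on a saturated chain carbon bound to an aromatic carbon. The step of a 1.1-fold higher number from compound 2 to compound 3 (0.04 log units; within the scatter) corresponds to furan-2-yl in place of pyridin-4-yl on an aromatic carbon, which is how the core of compound 2 differs from that of compound 3.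

Compound 4 `Cc1cccc(Nc2nccc(-c3ccco3)n2)c1` is not yet measured. It differs from compound 2 by hydrogen in place of methyl on a saturated chain carbon bound to an aromatic carbon, the same change as from compound 3 to compound 1, on the same place. Because the step of a 1.2-fold lower number from compound 3 to compound 1 (0.08 log units; within the scatter) is within the scatter, the step of a 1.1-fold lower number from compound 2 to compound 4 (0.06 log units; within the scatter) is expected to be of similar size. Given compound 2 at 9700 nM, compound 4 is estimated at 8500 nM, expected between 4500 nM and 17000 nM.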

Compound 4, half-maximal inhibitory concentration: 2100 nM
Beside the measured number, compound 4's estimate is 4.0-fold (0.61 log units) above it; measured number outside the range, below it.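

Hydrogen in place of methyl on a saturated chain carbon bound to an aromatic carbon does not carry over unchanged from one core to the other in this assay, where the core of compound 2 gives a 4.6-fold lower number from compound 2 to compound 4 (0.66 log units; beyond the scatter): the same change on two cores in this assay, a 1.2-fold lower number (0.08 log units; within the scatter) from compound 3 to compound 1 and a 4.6-fold lower number (0.66 log units; beyond the scatter) from compound 2 to compound 4, 3.8-fold (0.58 log units) apart, beyond the scatter of two such steps. Furan-2-yl in place of pyridin-4-yl likewise depends on the partner group, with a 4.2-fold lower number from compound 1 to compound 4 (0.62 log units; beyond the scatter): the same change on two cores in this assay, a 1.1-fold higher number (0.04 log units; within the scatter) from compound 2 to compound 3 and a 4.2-fold higher number (0.62 log units; beyond the scatter) from compound 4 to compound 1, 3.8-fold (0.58 log units) apart, beyond the scatter of two such steps. Both comparisons rest on the same four compounds and amount to one observation, set apart by compound 4 alone, which shows that the two places do not act independently here but neither explains this nor shows it holds more widely.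

Open, from the compounds shown here alone, is whether a longer chain such as propyl behaves the same way on either core. Also open, going by these compounds, is whether thiophen-2-yl in place of furan-2-yl keeps the lower number seen with compound 4.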